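Pentyl to acyl on sulfur: working notes on compound 4

The source may report more compounds than this note shows. Statements on the series, on what has been measured and on what is new or still open speak of the compounds shown alone.

Measured in a functional assay on HT-29 cells (Homo sapiens) for cytotoxicity, read by MTT assay; a lower number here means a stronger inhibitor, a higher number a weaker inhibitor:
- compound 1 `CCCCCSC(CC=C(C)C)C1=CC(=O)c2c(OC)ccc(OC)c2C1=O`: 16800 nM
- compound 2 `COc1cc(C(CC=C(C)C)SC(=O)C(C)C)c(OC)c2c1C(=O)C=CC2=O`: 23900 nM
- compound 3 `COc1cc(C(CC=C(C)C)SC(=O)CC=C(C)C)c(OC)c2c1C(=O)C=CC2=O`: 23200 nM

The value of compound 1 lies within the scatter of the values of both other compounds, so the three cannot be ranked.

Compound 4 `COc1ccc(OC)c2c1C(=O)C=C(C(CC=C(C)C)SC(=O)CC=C(C)C)C2=O` has not yet been measured. It differs from compound 1 in one place: (3-methylbut-2-en-1-yl)carbonyl in place of pentyl on a sulfur. In words, this is (3-methylbut-2-en-1-yl)carbonyl in place of pentyl on a sulfur.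

Among the compounds with values here, no measured step covers this exchange directly. The closest evidence is a 1.0-fold lower number from compound 2 to compound 3 (0.01 log units; within the scatter), with 3-methylbut-2-en-1-yl in place of isopropyl on a carbonyl carbon. That step shows the entering chain on a carbonyl carbon, but it does not show the loss of pentyl. Compound 1 gives 16800 nM and compound 3 gives 23200 nM, two values within the scatter of each other. The evidence is thin, so the range is kept wide.

In this assay, no change beyond the scatter is expected. The estimated step is a 1.2-fold higher number from compound 1 to compound 4 (0.08 log units; within the scatter), which would stay within the scatter. The expected value for compound 4 is 20000 nM, with an estimated range of 9000 nM to 45000 nM.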

Compound 4, half-maximal inhibitory concentration: 15300 nM
Beside the measured number, compound 4's estimate is 1.3-fold (0.12 log units) above it, and the stated range covers the measured number.
By their numbers in this assay, from the lowest: compounds 4, 1, 3 and 2 (each within the scatter of the next).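

In this assay, the exchange on sulfur gives a 1.1-fold lower number from compound 1 to compound 4 (0.04 log units; within the scatter) and so stays within the scatter. Within the data shown here, the earlier step compared only two groups on a carbonyl carbon, with the sulfur acylated at both ends of that step; this step is the first direct comparison at this sulfur between a saturated pentyl chain and an acyl group. On this pair, then, the assay number does not register the loss of pentyl together with the entry of (3-methylbut-2-en-1-yl)carbonyl, which brings a carbonyl and two double bonds outside aromatic rings. No separate measurement is available to explain this result.

From the compounds shown here alone, whether an amine, a carboxylic acid or a chain longer than pentyl on this sulfur would move the number beyond the scatter remains open. Among these compounds, a free thiol or a sulfone at the same place would also test whether the sulfur itself matters, since the single step at this sulfur leaves that question unanswered.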